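Swapping a furan for a pyridine on an oxazole ketone

The source may report more compounds than this note shows. Statements on the series, on what has been measured and on what is new or still open speak of the compounds shown alone.

Measured so far:
compound 1 `CCCCCCCC/C=C\CCCCCCC(=O)c1ncc(-c2ccoc2)o1` gives 610 nM
compound 2 `O=C(CCCc1ccccc1)c1nc2ncccc2o1` gives 6.9 nM

In an assay on isolated protein for inhibition of Fatty-acid amide hydrolase 1 (Homo sapiens) (on this read-out lower numbers stand for stronger inhibition and higher numbers for weaker inhibition), compound 1 stands highest of the two numbers, meaning the weaker inhibitor of the pair. Compound 2, built on a different core with a short chain ending in a benzene ring, gives the far lower number; no single-place comparison between the two is available, so only the two values themselves can be set side by side. Compound 3 `CCCCCCCC/C=C\CCCCCCC(=O)c1ncc(-c2cccnc2)o1` differs from compound 1 in one place: pyridin-3-yl in place of furan-3-yl on an aromatic carbon. Among the compounds with values here, with no comparable pair measured, the size of the change is uncertain; a moderate drop in the number, beyond the scatter, is expected, since a nitrogen-containing aromatic ring in compound 2 accompanies its low 6.9 nM. Compound 3 is expected to give about 150 nM, in the range 30 nM to 600 nM, meaning a step of a 4.1-fold lower number from compound 1 to compound 3 (0.61 log units; beyond the scatter).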

Compound 3, inhibition constant: 61 nM
Compound 3: middle estimate off by 2.5-fold (0.39 log units), on the high side; the measured number falls inside the stated range.
By their numbers in this assay, from the lowest: compound 2; then compound 3; then compound 1.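

In this assay, putting pyridin-3-yl in place of furan-3-yl while the rest of the molecule stays the same gives a 10-fold lower number from compound 1 to compound 3 (1.00 log units; beyond the scatter). This single-place comparison shows that the aromatic ring on this carbon, next to the ring oxygen of the core, affects the read-out by more than the usual scatter. The swap changes the ring size and the hetero atom together, and nothing measured here shows which of these matters or explains why the number falls.

From the compounds shown here alone, it remains open whether a plain phenyl ring, with no hetero atom, would give a similar number. Also open, going by these compounds, is whether the ring nitrogen's place matters, which pyridin-2-yl or pyridin-4-yl at this same carbon would test.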